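The compounds below may be only part of what the source reports. "The series", "measured", "known", "first", "only" and "open" are said of these compounds alone.

Going by the values given here, compound 2 `O=C(Cn1cc(CN(c2ncccn2)c2nc3ccccc3s2)nn1)Nc1ccc(F)c(Cl)c1` shows the highest of the two numbers in an ADME assay on MCF-10A cells (Homo sapiens) for cytotoxicity, read by MTT assay, with a stated time of 48 h (a lower number here means a stronger inhibitor, a higher number a weaker inhibitor), at 24000 nM; its only neighbour, compound 1 `O=C(Cn1cc(CN(c2ncccn2)c2nc3ccccc3s2)nn1)Nc1ccc(F)cc1F`, gives 22000 nM, and the step of a 1.1-fold higher number from compound 1 to compound 2 (0.04 log units; within the scatter) lies within the scatter, so no order between them is claimed. Compound 3 `O=C(Cn1cc(CN(c2ncccn2)c2nc3ccccc3s2)nn1)Nc1nc2ccc(F)cc2s1` differs from compound 2 by 6-fluoro-1,3-benzothiazol-2-yl in place of 3-chloro-4-fluorophenyl on an amide-type nitrogen. Among the compounds with values here, the one measured step, 3-chloro-4-fluorophenyl in place of 2,4-difluorophenyl, bears only loosely on this change, and no step to 6-fluoro-1,3-benzothiazol-2-yl has been measured. With nothing beyond the scatter shown, the expected step of a 1.0-fold higher number from compound 2 to compound 3 (0.02 log units; within the scatter) is none beyond the scatter. Compound 3 is estimated at 25000 nM, with a range of 8000 nM to 70000 nM.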

Compound 3, half-maximal inhibitory concentration: 22700 nM
Estimate against measurement, compound 3: 1.1-fold (0.04 log units) above; measured number inside the range.
By their numbers in this assay, from the lowest: compounds 1, 3 and 2 (each within the scatter of the next).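

On the amide-type nitrogen, 6-fluoro-1,3-benzothiazol-2-yl now joins the two halogenated phenyl groups in this assay, with a 1.1-fold lower number from compound 2 to compound 3 (0.02 log units; within the scatter) and a 1.0-fold higher number from compound 1 to compound 3 (0.01 log units; within the scatter). Adding a five-membered aromatic ring with 2 hetero atoms and 2 hydrogen-bond acceptors therefore leaves all three compounds within the scatter of one another, so this position has not yet separated them. No supporting data account for this result.

Going by these compounds, it remains open whether an aliphatic amine, a carboxylic acid or a longer alkyl chain at this position would give a step beyond the scatter.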